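A new group on the ring amine nitrogen

The source may hold more compounds than are shown below. What is called first, only, known or untested is meant among the compounds shown, and "the series" means these compounds.

Compound 2 `CS(=O)(=O)c1cnc(O[C@H]2CC[C@H](OC3CCN(C(=O)Oc4ccccc4)CC3)CC2)cn1` was measured in a functional assay on isolated protein for agonist activity at Glucose-dependent insulinotropic receptor (Homo sapiens), read by HTRF and cAMP accumulation (on this read-out higher numbers stand for larger maximal responses and lower numbers for smaller maximal responses), where compound 2 gives 116%. Going by the values given here, its only neighbour among the numbers in hand is compound 1 `CC(C)(C)OC(=O)N1CCC(O[C@H]2CC[C@@H](Oc3ccc(S(C)(=O)=O)cc3)CC2)CC1`, which gives 120% in this assay, a gap that lies within the scatter. Compound 3 `CC(F)Cc1nc(CN2CCC(O[C@H]3CC[C@H](Oc4cnc(S(C)(=O)=O)cn4)CC3)CC2)no1` has not yet been measured and differs from compound 2 in one place: (5-(2-fluoropropyl)-1,2,4-oxadiazol-3-yl)methyl in place of phenoxycarbonyl on an amine nitrogen in a ring. Among the compounds with values here, no step between measured compounds is in hand, so the step of a number 6 percentage points lower from compound 2 to compound 3 (within the scatter) is expected to be small, with no direction beyond the scatter. In this assay compound 3 is therefore estimated at 110%, between 85% and 130%.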

Compound 3, largest response reached (Emax), in percent of the reference or control that the assay uses: 97%
Estimate against measurement, compound 3: 13 percentage points above; the range from low to high includes it.
By their numbers in this assay, from the lowest: compound 3; then compounds 2 and 1 (each within the scatter of the next).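

Going by these compounds alone, putting (5-(2-fluoropropyl)-1,2,4-oxadiazol-3-yl)methyl in place of phenoxycarbonyl on the amine nitrogen in a ring gives the only step in hand at this position in this assay, a number 19 percentage points lower from compound 2 to compound 3 (beyond the scatter), so the group on this nitrogen can change the maximal response. The change is modest, and compound 3 still gives 97%. Nothing in hand bears on the reason for this step. As far as these compounds go, it remains open whether the step follows from the loss of the carbonyl or from the oxadiazole ring that enters, which a benzyl group or a simple amide on this nitrogen could help to separate. From the compounds shown here alone, the part played by the fluorine, which a plain propyl chain would test, is also open.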